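The source may hold more compounds than are shown below. What is called first, only, known or untested is meant among the compounds shown, and "the series" means these compounds.

Measured so far:
compound 1, `O=C(O)COc1ccc(Cl)cc1C#Cc1ccccc1` — 108 nM
compound 2, `COc1ccccc1C#Cc1cc(Cl)ccc1OCC(=O)O` — 190 nM
compound 3, `O=C(O)COc1ccc(Cl)cc1C#Cc1ccc(Cl)cc1` — 60 nM

In an assay on CHO cells for displacement of a labelled ligand from prostaglandin D2 receptor 2 (Homo sapiens), read by scintillation counting (a higher number here means a weaker inhibitor, a lower number a stronger inhibitor), compound 1 gives 108 nM, the second highest of the three numbers. The two steps from it, a 1.8-fold higher number from compound 1 to compound 2 (0.25 log units; within the scatter) and a 1.8-fold lower number from compound 1 to compound 3 (0.26 log units; within the scatter), both stay within the scatter, so the ring bearing the alkyne substituent has so far tolerated a methoxy and a chloro without a clear shift.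

Compound 4, `CCCS(=O)(=O)c1cccc(C#Cc2cc(Cl)ccc2OCC(=O)O)c1`, differs from compound 1 as follows: propylsulfonyl in place of hydrogen on an aromatic carbon. For the measured compounds named here, neither measured step involves a propylsulfonyl or any group of comparable size, so no measured step bears directly on this change, and the two that exist point in no consistent direction. Compound 4 is therefore expected to land near compound 1, at 90 nM (range 25 nM to 320 nM), the expected step being a 1.2-fold lower number from compound 1 to compound 4 (0.08 log units; within the scatter), with a wide range given the lack of a matching precedent.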

Compound 4, inhibition constant: 9 nM
Beside the measured number, compound 4's estimate is 10-fold (1.00 log units) above it; the whole stated range lies above it.
By their numbers in this assay, from the lowest: compound 4; then compounds 3, 1 and 2 (each within the scatter of the next, the first and the last beyond it).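

In this assay the step of a 12-fold lower number from compound 1 to compound 4 (1.08 log units; beyond the scatter) comes with propylsulfonyl on an aromatic carbon meta to a large group. For the compounds shown here, it is the first step from compound 1 beyond the scatter, whereas the methoxy and chloro steps stayed within it. The series therefore does respond to substitution on this ring, and this large, unbranched group is accepted here. Nothing available explains the gain.

Open, as far as these compounds go, is whether the sulfonyl or the propyl chain carries the gain. Methylsulfonyl, a longer butylsulfonyl chain or a sulfonamide would separate the two.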